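Swapping the aryl cap on a fluorinated hydroxamic acid

The source may report more compounds than this note shows. Statements on the series, on what has been measured and on what is new or still open speak of the compounds shown alone.

Three compounds sharing a long fluorinated chain that ends in a hydroxamic acid have been measured in an assay on isolated protein for inhibition of histone deacetylase 8 (Homo sapiens), read by fluorescence; on this read-out higher numbers stand for weaker binding and lower numbers for tighter binding. Compound 1, `CC(=O)Nc1ccc(NC(=O)C(F)(F)C(F)(F)C(F)(F)C(F)(F)C(F)(F)C(F)(F)C(=O)NO)cc1`, gives 36000 nM. Compound 2, `O=C(NO)C(F)(F)C(F)(F)C(F)(F)C(F)(F)C(F)(F)C(F)(F)C(=O)Nc1ccc(-c2cn(-c3ccccc3)nn2)cc1`, reaches only a limit of the assay, > 100000 nM. Compound 3, `O=C(NO)C(F)(F)C(F)(F)C(F)(F)C(F)(F)C(F)(F)C(F)(F)C(=O)Nc1nc(-c2ccccc2)cs1`, gives 1500 nM. The step of an at least 2.7-fold higher number from compound 1 to compound 2 (0.44 log units; beyond the scatter) and the step of a 24-fold lower number from compound 1 to compound 3 (1.38 log units; beyond the scatter) show that the aryl group on the amide-type nitrogen changes the outcome strongly, with compound 3 holding the lowest number of the two that were read as numbers.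

Compound 4, `O=C(NO)C(F)(F)C(F)(F)C(F)(F)C(F)(F)C(F)(F)C(F)(F)C(=O)Nc1ccccc1-c1ccccc1`, differs from compound 3 in the same region: 2-phenylphenyl in place of 4-phenyl-1,3-thiazol-2-yl on an amide-type nitrogen. Among the compounds with values here, only the step from compound 1 to compound 3 bears directly on such an exchange of the aryl group, and it was large, so a step beyond the scatter in either direction is plausible; with the thiazole removed, a somewhat higher number is expected. The estimate for compound 4 is a step of a 3.3-fold higher number from compound 3 to compound 4 (0.52 log units; beyond the scatter), giving a value of 5000 nM, between 1000 nM and 30000 nM.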

Compound 4, dissociation constant: 5300 nM
The estimate for compound 4 lay 1.1-fold (0.03 log units) below the measured number; the range from low to high includes it.
By their numbers in this assay, from the lowest: compound 3; then compound 4; then compound 1. At a limit, above all of these: compound 2.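

In this assay, 2-phenylphenyl on the amide-type nitrogen gives a 3.5-fold higher number from compound 3 to compound 4 (0.55 log units; beyond the scatter), so the cap with only carbon atoms and no hydrogen-bond acceptors binds less tightly than the thiazole-containing cap but still gives a measurable number. Replacing 4-acetamidophenyl with 2-phenylphenyl gives a 6.8-fold lower number from compound 1 to compound 4 (0.83 log units; beyond the scatter), showing that a cap need not contain the nitrogen and sulfur of the thiazole to give a lower number than compound 1. Compound 2 remains a limit, not a number: the limit of > 100000 nM in this assay, at which 1 of the 4 values shown sits.

The exchange replaces a whole two-ring group at once, so these compounds cannot separate the effect of the ring atoms from that of how the two rings are joined. Also open, going by these compounds, is how an amine or a carboxylic acid on the cap, or a chain without fluorine, would change the number.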